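This account rests on a few compounds, and the source may have more. Where it says the series, first, only, none or still open, it means among the compounds named here.

Compound 1, `c1ccc(N2CCN(CCCOc3cccc4c3CCC4)CC2)cc1`, was tested in a functional assay on the whole organism for inhibition, with Mus musculus as the target, at a dose of 25 mg/kg by the oral route (on this read-out higher numbers stand for more inhibition at the one dose given (going by the name of the read-out) and lower numbers for less inhibition), and compound 1 gives 0%. Compound 2, `Fc1ccc(N2CCN(CCCOc3cccc4c3CCC4)CC2)cc1`, carries one change against compound 1: fluoro in place of hydrogen on an aromatic carbon. In this assay compound 2 gives 5%, so the step reads a number 5 percentage points higher from compound 1 to compound 2 (within the scatter), and nothing is gained by it beyond the usual scatter.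

Compound 3, `c1ccc(C2CCc3ccc(OCCCN4CCN(c5ccccc5)CC4)cc32)cc1`, has a different core; the difference between the two cores is not broken down here. In this assay compound 3 gives 0%, the same figure at the digits shown as compound 1 and, with compound 1, the lowest of the three numbers.

Compound 4, `Fc1ccc(N2CCN(CCCOc3ccc4c(c3)C(c3ccccc3)CC4)CC2)cc1`, has not been measured. Against compound 3 it shows (fluoro in place of hydrogen on an aromatic carbon), the same change that leads from compound 1 to compound 2, at the same kind of place. Because that earlier step gave a number 5 percentage points higher from compound 1 to compound 2 (within the scatter), the step from compound 3 to compound 4 is expected to be about as small, a number 4 percentage points higher from compound 3 to compound 4 (within the scatter), resting only on that one pair. Compound 4 is therefore estimated to give 4% in this assay, most likely between 0% and 15%.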

Compound 4, a percentage reported as inhibition, in the whole organism at one dose (the size of the read-out at that dose, not a potency): 17%
Estimate against measurement, compound 4: 13 percentage points below; the measured number lies above the stated range.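

On the core of compound 3, the change from phenyl to 4-fluorophenyl gives a number 17 percentage points higher from compound 3 to compound 4 (beyond the scatter) in this assay, and this step stands clear of the usual scatter. Set beside the same change on the core of compound 1, this step cannot be told apart from the earlier one: the same change on two cores in this assay, a number 5 percentage points higher (within the scatter) from compound 1 to compound 2 and a number 17 percentage points higher (beyond the scatter) from compound 3 to compound 4, 12 percentage points apart, within the scatter of two such steps The change therefore carries across these two cores with no measurable difference in the size of its effect, but two pairs tested at a single oral dose do not prove that the effect is the same on both cores, and they say nothing about any other core.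

Going by these compounds, it remains open whether a different group on the same ring, such as chloro, methoxy or trifluoromethyl, would behave as fluoro does. A longer chain linking the core to the rest of the molecule is also untested among the compounds shown, as is the effect of a change at other doses.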